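Trimming trifluoromethyl to fluoro on the aromatic ring

The source may hold more compounds than are shown below. What is called first, only, known or untested is meant among the compounds shown, and "the series" means these compounds.

Values in a functional assay on DU-145 cells (Homo sapiens) for inhibition (a higher number here means a weaker inhibitor of growth, a lower number a stronger inhibitor of growth), so far:
- compound 1 `O=S(=O)(/C=C/c1ccc(F)cc1)Cc1ccc(Nc2ncnc3ccccc23)cc1` gives 300 nM
- compound 2 `O=S(=O)(/C=C/c1ccc(Cl)cc1Cl)Cc1ccc(Nc2ncnc3ccccc23)cc1` gives 3000 nM
- compound 3 `O=S(=O)(/C=C/c1ccc(C(F)(F)F)cc1F)Cc1ccc(Nc2ncnc3cc(Cl)ccc23)cc1` gives > 100000 nM as a limit

Compound 3 reaches only a limit (the limit of > 100000 nM in this assay, at which 1 of the 3 values shown sits). Compound 4 `O=S(=O)(/C=C/c1ccc(F)cc1F)Cc1ccc(Nc2ncnc3cc(Cl)ccc23)cc1` differs from it in one place: fluoro in place of trifluoromethyl on an aromatic carbon (fluoro in place of trifluoromethyl on an aromatic carbon, para to a large group). Within the data shown here, the one measured step on this ring is a 10-fold higher number from compound 1 to compound 2 (1.00 log units; beyond the scatter) where 2,4-dichlorophenyl replaced 4-fluorophenyl on a different core. After that step, a clear move toward a lower number is expected in this assay for the smaller group, though its size stays uncertain without a starting number. The estimated change is an at least 10-fold lower number from compound 3 to compound 4 (1.00 log units; beyond the scatter) in this comparison. For compound 4 the expected value is 10000 nM with a range of 1500 nM to 70000 nM in the same test.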

Compound 4, concentration for 50% growth inhibition: > 100000 nM
Compound 4 gave a limit, no number (the forecaster's own chance of this, stated with the estimate: 20%); middle value at least 10-fold (1.00 log units) away from the limit.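

Compound 3 and compound 4 both stop at a limit rather than a number, so no step between them can be read: the limit of > 100000 nM in this assay, at which 2 of the 4 values shown sit.

Going by these compounds, whether fluoro in place of trifluoromethyl changes growth inhibition at all stays open.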